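Sulfonamide hydrazides: aroyl in place of aryl on hydrazide

This account rests on a few compounds, and the source may have more. Where it says the series, first, only, none or still open, it means among the compounds named here.

Measured compounds:
compound 1, `O=C(NNc1ccc(F)cc1)c1ccc(NS(=O)(=O)c2cnc(O)nc2O)cc1` — in a functional assay on SGC-7901 cells (Homo sapiens) for antiproliferative activity, read by MTT assay, with a stated time of 24 h (on this read-out higher numbers stand for weaker inhibition and lower numbers for stronger inhibition), compound 1 gives > 20000 nM, a limit of the assay.
compound 2, `Cc1ccccc1NNC(=O)c1cccc(NS(=O)(=O)c2cnc(O)nc2O)c1` — in this assay compound 2 gives > 20000 nM, a limit of the assay.

Neither value is a number. Compound 2 stands where both shown values stand, at the limit of > 20000 nM in this assay, at which 2 of the 2 values shown sit, and nothing in the pair separates it from compound 1. Compound 3, `O=C(NNC(=O)c1cccc(NS(=O)(=O)c2cnc(O)nc2O)c1)c1ccc(F)cc1`, is not yet measured. It differs from compound 2 by (4-fluorophenyl)carbonyl in place of 2-methylphenyl on an amine nitrogen. Among the measured compounds shown here, no step between measured compounds exists to scale this change, and no measured compound offers a number to step from. In this assay the change from compound 2 to compound 3 is expected to give no step beyond the scatter, with the result most likely again a limit. Compound 3 is expected at 25000 nM, within 8000 nM to 60000 nM. That expectation means a step that the limit leaves unreadable from compound 2 to compound 3.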

Compound 3, half-maximal inhibitory concentration: > 20000 nM
Compound 3: only a limit was reported; the forecaster's own chance of this, stated with the estimate: 80%; the middle value does not contradict the limit.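

No step can be read from compound 2 to compound 3, since each stands at a limit of the assay: the limit of > 20000 nM in this assay, at which 3 of the 3 values shown sit.
The compounds shown leave open whether (4-fluorophenyl)carbonyl in place of 2-methylphenyl changes anything in this assay, and how far any of the three lies past that limit.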